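A few compounds are considered here, and "the series" means these few. Any claim that something is new, unique, unknown or untested is made for them only; others in the source may bear on it.

Of the compounds shown here, two of a shared core have been tested. Compound 1 `O=C1/C(=C/c2ccc(Cl)cc2)CCC/C1=C\c1ccc([N+](=O)[O-])cc1` carries a chloro group on one of its two aryl arms; in a functional assay on HSC-2 cells (Homo sapiens) for cytotoxicity (a higher number here means that more compound is tolerated, a lower number that less compound is tolerated), compound 1 gives 1500 nM. Compound 2 `COc1cc(/C=C2\CCC/C(=C\c3ccc([N+](=O)[O-])cc3)C2=O)cc(OC)c1OC` carries three methoxy groups on the corresponding arm, and in this assay compound 2 gives 760 nM. Compound 1 has the higher of the two numbers, but the gap to compound 2 lies within the usual scatter, so no order between them can be read from these data.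

Compound 3 `COc1ccc(/C=C2\CCC/C(=C\c3ccc([N+](=O)[O-])cc3)C2=O)cc1` is the next compound. It differs from compound 1 by methoxy in place of chloro on an aromatic carbon, so that a 4-chlorophenyl arm becomes a 4-methoxyphenyl arm. Since both measured compounds sit close together, no step beyond the scatter is expected from compound 1 to compound 3, and the change expected is a 1.4-fold lower number from compound 1 to compound 3 (0.13 log units; within the scatter). For compound 3 the estimate in this assay is 1100 nM, with a range from 450 nM to 2700 nM.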

Compound 3, half-maximal cytotoxic concentration: > 400000 nM
Compound 3: only a limit was reported (the forecaster's own chance of this, stated with the estimate: 5%); middle value at least 360-fold (2.56 log units) from the limit.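

The two earlier compounds gave no sign that the aryl arm mattered much, but this position proves highly sensitive: replacing chloro with methoxy gives an at least 260-fold higher number from compound 1 to compound 3 (2.42 log units; beyond the scatter) in this assay. This large shift comes from exchanging a single chlorine for a two-atom group, with the rest of the molecule unchanged. In this assay, compound 3 gives only a limit, > 400000 nM, and the true size of the step remains unknown because the reading stops there: the limit of > 400000 nM in this assay, at which 1 of the 3 values shown sits.

The compounds shown leave open how a methyl, a hydroxy or an amine at this place would compare with chloro and methoxy. They also leave open whether the same exchange would have so large an effect with a group other than the nitro on the second aryl arm.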